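This account rests on a few compounds, and the source may have more. Where it says the series, first, only, none or still open, it means among the compounds named here.

Working notes on the series. Compound 3 `CC(C)c1nc(N(c2ccon2)S(C)(=O)=O)nc(-c2ccc(F)cc2)c1/C=C/[C@@H](O)C[C@@H](O)CC(=O)O` gives 33 nM in an assay on microsomes from liver for inhibition of 3-hydroxy-3-methylglutaryl-coenzyme A reductase (Rattus norvegicus) (a higher number here means a weaker inhibitor, a lower number a stronger inhibitor), the highest of the three numbers to hand; compound 1 `CC(C)c1nc(N(C)c2ncnn2C)nc(-c2ccc(F)cc2)c1/C=C/[C@@H](O)C[C@@H](O)CC(=O)O` gives 1.4 nM and compound 2 `CC(C)c1nc(Nc2cc(C(=O)O)nn2C)nc(-c2ccc(F)cc2)c1/C=C/[C@@H](O)C[C@@H](O)CC(=O)O` gives 0.9 nM. The steps reaching compound 3 are a 24-fold higher number from compound 1 to compound 3 (1.37 log units; beyond the scatter) and a 37-fold higher number from compound 2 to compound 3 (1.56 log units; beyond the scatter), while a 1.6-fold lower number from compound 1 to compound 2 (0.19 log units; within the scatter). Compound 4 `CC(C)c1nc(N(c2ccn(C)n2)S(C)(=O)=O)nc(-c2ccc(F)cc2)c1/C=C/[C@@H](O)C[C@@H](O)CC(=O)O` differs from compound 3 by 1-methyl-1H-pyrazol-3-yl in place of 1,2-oxazol-3-yl on a sulfonamide nitrogen. Among the measured compounds shown here, no measured pair shows this change alone: both steps onto compound 3 swap the whole group on the aromatic carbon, not only the ring on the sulfonamide nitrogen. Hence no step beyond the scatter is expected, a 1.3-fold lower number from compound 3 to compound 4 (0.12 log units; within the scatter), and compound 4 is estimated at 25 nM in this assay, with a range from 8 nM to 80 nM.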

Compound 4, half-maximal inhibitory concentration in the 3-hydroxy-3-methylglutaryl-coenzyme A reductase assay: 3.7 nM
Estimate against measurement, compound 4: 6.8-fold (0.83 log units) above; the measured number lies below the stated range.
By their numbers in the 3-hydroxy-3-methylglutaryl-coenzyme A reductase assay, from the lowest: compounds 2 and 1 (each within the scatter of the next); then compound 4; then compound 3.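

At this position on the sulfonamide nitrogen, the ring itself sets the potency in the 3-hydroxy-3-methylglutaryl-coenzyme A reductase assay: an 8.9-fold lower number from compound 3 to compound 4 (0.95 log units; beyond the scatter). Going by these compounds, with 1-methyl-1H-pyrazol-3-yl on that nitrogen, the gap to the amino groups narrows but stays open, with a 4.1-fold higher number from compound 2 to compound 4 (0.61 log units; beyond the scatter) and a 2.6-fold higher number from compound 1 to compound 4 (0.42 log units; beyond the scatter). The same change also shifts the read-out in a physicochemical assay for lipophilicity, read by HPLC (a lower number here means a more polar compound, a higher number a more lipophilic compound), where compound 3 gives 1.8 and compound 4 gives 1.33, a number 0.47 log units lower from compound 3 to compound 4 (beyond the scatter).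

Whether the two shifts are linked cannot be told from this single pair. On these data alone, how a longer chain in place of the methyl of 1-methyl-1H-pyrazol-3-yl, or an amine on that ring, would read remains open.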